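The source may hold more compounds than are shown below. What is called first, only, known or untested is meant among the compounds shown, and "the series" means these compounds.

Measured compounds:
Compound 1, `CCN(CC)S(=O)(=O)c1ccc(S(=O)(=O)N2CCC[C@@H](C(=O)N(C)C(C)C)C2)cc1`, gives 1400 nM in a functional assay on MIA PaCa-2 cells (Homo sapiens) for inhibition, read by MTT assay, with a stated time of 3 days; on this read-out higher numbers stand for weaker inhibition and lower numbers for stronger inhibition.
Compound 2, `CCN(CC)S(=O)(=O)c1ccc(S(=O)(=O)N2CCC[C@@H](C(=O)N3CCN(c4nnc(C(C)C)o4)CC3)C2)cc1`, gives 1000 nM in this assay.

Compound 1 has the highest of the two numbers, but its nearest neighbour, compound 2, lies within the usual scatter of the measurement, so the two cannot be told apart on this read-out.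

Compound 3, `CCN(CC)S(=O)(=O)c1ccc(S(=O)(=O)N2CCC[C@@H](c3cc(C)no3)C2)cc1`, has not yet been measured. It differs from compound 1 in one place: 3-methyl-1,2-oxazol-5-yl in place of isopropyl(methyl)carbamoyl on a saturated ring carbon. Among the compounds with values here, no measured pair shows this exchange, so its effect cannot be read from the data at hand. The expectation is for a small step in this assay, not clearly beyond the scatter, leaning if anything toward a higher number. Compound 3 is therefore expected to give about 1600 nM in this assay, with a likely range from 400 nM to 6000 nM. This estimate corresponds to an expected step of a 1.1-fold higher number from compound 1 to compound 3 (0.06 log units; within the scatter).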

Compound 3, half-maximal inhibitory concentration: 2700 nM
For compound 3 the middle estimate is 1.7-fold (0.23 log units) below the measured one; low and high end bracket the measured number.
By their numbers in this assay, from the lowest: compounds 2, 1 and 3 (each within the scatter of the next, the first and the last beyond it).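

Replacing isopropyl(methyl)carbamoyl with 3-methyl-1,2-oxazol-5-yl on this saturated ring carbon gives a 1.9-fold higher number from compound 1 to compound 3 (0.29 log units; within the scatter) in this assay, so the two compounds cannot be told apart on this read-out. For this pair, then, an open-chain amide group and a five-membered aromatic ring with 2 hetero atoms serve about equally at this position, and the carbonyl of the amide is not needed to keep a number of this size. No measurement at hand explains why the two groups behave alike.

The compounds shown leave open whether the methyl group on the new ring matters, since the same ring without it does not appear among them. They also leave open whether a carboxylic acid, an amine or a longer alkyl chain on this carbon would move the number beyond the scatter.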